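Butylamino replacing chloro on the shared core of compound 2

The source may hold more compounds than are shown below. What is called first, only, known or untested is meant among the compounds shown, and "the series" means these compounds.

Compound 2 `O=C(NCc1ccccc1)c1cnc(Cl)cn1` carries a chloro group on its core; in an ADME assay on MDCK cells (Canis lupus familiaris) for cytotoxicity, read by microscopy, with a stated time of 6 days (a higher number here means that more compound is tolerated, a lower number that less compound is tolerated), compound 2 gives "not determined" (no result reported), so no number stands for it. For the measured compounds named here, the only measured member of the series is compound 1 `CCCCCCCCNc1cnc(C(=O)NCc2ccccc2)cn1`, which carries an octylamino group in the same position. In this assay, going by the values given here, compound 1 gives >= 20000 nM; this is a limit of the assay, not a number, and the limit of >= 20000 nM in this assay, at which 1 of the 2 values shown sits, marks it as the only value returned so far. Compound 3 `CCCCNc1cnc(C(=O)NCc2ccccc2)cn1` is to be measured in this assay. It differs from compound 2 by butylamino in place of chloro on an aromatic carbon. No step between two measured compounds is shown, so the size of the change from compound 2 to compound 3 in this assay cannot be read from the series; with compound 1 sitting at the limit, the most that can be said is that compound 3, a shorter homologue of compound 1, is expected to be tolerated to a similar degree, with no direction of change beyond the scatter foreseen. For compound 3 in this assay the estimate is 20000 nM, with a range from 7000 nM to 40000 nM, and a limit value rather than a number is the most likely outcome.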

Compound 3, minimum cytotoxic concentration: 100000 nM
Beside the measured number, compound 3's estimate is 5.0-fold (0.70 log units) below it, outside the stated range (above it).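

No new step can be read in this assay: compound 1 gives >= 20000 nM, a limit of the assay and not a number, so the change from compound 1 to compound 3 has no readable size, and compound 2 has no number. The compounds shown leave open whether moving from butylamino to octylamino changes tolerance at all, and where chloro stands relative to either.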